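Anilino replacement at the aryl terminus of the diene series

The source may report more compounds than this note shows. Statements on the series, on what has been measured and on what is new or still open speak of the compounds shown alone.

Working notes on a small set of compounds sharing the core of compound 1 `C=C[C@@](C)(/C=C/c1ccc(OC)cc1)CCC=C(C)C`, all tested in an ADME assay on BJ cells (Homo sapiens) for cytotoxicity, with a stated time of 72 h; a lower number here means that less compound is needed, a higher number that more compound is needed for the effect. In this assay compound 1 gives a value that is a limit of the assay, > 36600 nM. Compound 2 `C=C[C@@](C)(/C=C/c1ccc(O)c(C=O)c1)CCC=C(C)C` likewise reaches only a limit in this assay, > 36600 nM. Compound 3 `CCOC(=O)/C=C/c1cc(/C=C/[C@](C)(/C=C/c2ccc(OC)cc2)CCC=C(C)C)ccc1O` also sits at a limit in this assay, > 36600 nM. Where compound 1 stands can thus be described only by that limit: the limit of > 36600 nM in this assay, at which 3 of the 3 values shown sit, so no ranking among compounds 1, 2 and 3 can be drawn and no measured step between any two of them exists.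

The next compound, compound 4 `C=C[C@@](C)(/C=C/c1ccc(Nc2ccc(Cl)cc2)cc1)CCC=C(C)C`, differs from compound 1 in one place: (4-chlorophenyl)amino in place of methoxy on an aromatic carbon. Among the compounds with values here, with nothing measured beyond the limit, no step in this assay can be set against this change. The expectation is that the change from compound 1 to compound 4 stays within the scatter of this assay, in no clear direction, giving an estimated step of an at least 1.2-fold lower number from compound 1 to compound 4 (0.08 log units; that floor lies within the scatter). Compound 4 is accordingly estimated at 30000 nM, within a range from 8000 nM to 100000 nM, with a fair chance that this assay again reports only a limit.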

Compound 4, half-maximal effective concentration: > 36600 nM
Compound 4: only a limit was reported; the forecaster's own chance of this, stated with the estimate: 55%; middle value at least 1.2-fold (0.08 log units) away from the limit.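

Compound 4 also gives only a limit in this assay, > 36600 nM. Compound 1 sits at a limit as well, so no step between compound 1 and compound 4 can be read: the limit of > 36600 nM in this assay, at which 4 of the 4 values shown sit.

The compounds shown leave open how (4-chlorophenyl)amino in place of methoxy on an aromatic carbon shifts the read-out in this assay.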